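This account rests on a few compounds, and the source may have more. Where it says the series, first, only, none or still open, it means among the compounds named here.

Three compounds share one core. In an ADME assay on MT4 cells (Homo sapiens) for cytotoxicity, read by MTT assay, with a stated time of 4 days (on this read-out higher numbers stand for lower toxicity in this test and lower numbers for higher toxicity in this test), compound 1 `COc1ccccc1Oc1nc(Nc2ccc(C#N)cc2)nc2ccccc12` gives 150000 nM. In this assay compound 3 `COc1cc(C#N)cc(Cl)c1Oc1nc(Nc2ccc(C#N)cc2)nc2ccccc12` gives 220000 nM. Compound 2 `COc1cc(C#N)ccc1Oc1nc(Nc2ccc(C#N)cc2)nc2ccccc12` reaches only a limit of this assay, >= 140000 nM. Both measured steps, a step that the limit leaves unreadable from compound 1 to compound 2 and a step that the limit leaves unreadable from compound 2 to compound 3, stay unreadable owing to the limit of >= 140000 nM in this assay, at which 1 of the 3 values shown sits. Compound 4 `Cc1cc(C#N)cc(C)c1Oc1nc(Nc2ccc(C#N)cc2)nc2ccccc12` carries 4-cyano-2,6-dimethylphenyl in place of 4-cyano-2-methoxyphenyl on an oxygen on an aromatic ring. Neither measured step can be read, and neither makes this change, so no step beyond the scatter is expected from compound 2 to compound 4, a step that the limit leaves unreadable from compound 2 to compound 4. For compound 4 the estimate in this assay is 180000 nM, expected to lie between 90000 nM and 360000 nM, with a fair chance that this assay again reports only a limit for compound 4.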

Compound 4, half-maximal cytotoxic concentration: 203000 nM
Compound 4: middle estimate off by 1.1-fold (0.05 log units), on the low side; low and high end bracket the measured number.
By their numbers in this assay, from the lowest: compounds 1, 4 and 3 (each within the scatter of the next).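

In this assay, the change on an oxygen on an aromatic ring can now be read once: 4-cyano-2,6-dimethylphenyl in place of 2-methoxyphenyl gives a 1.4-fold higher number from compound 1 to compound 4 (0.13 log units; within the scatter). This place therefore takes 4-cyano-2,6-dimethylphenyl with no step beyond the scatter. The steps to and from compound 2, including the exchange of 4-cyano-2-methoxyphenyl itself, still cannot be read: the limit of >= 140000 nM in this assay, at which 1 of the 4 values shown sits.

As far as these compounds go, how 4-cyano-2-methoxyphenyl and 4-cyano-2,6-dimethylphenyl truly compare stays open. So does whether a phenyl carrying an amine or a carboxylic acid in place of the nitrile would leave the scatter.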